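Methoxy in place of hydrogen on the shared core

This account rests on a few compounds, and the source may have more. Where it says the series, first, only, none or still open, it means among the compounds named here.

Compound 1 `CCC(=O)N1N=C(c2ccccc2)CC1c1ccc(Cl)cc1` is among the weaker inhibitors in this set. In an assay on isolated protein for inhibition of Amine oxidase [flavin-containing] B (Bos taurus) (a higher number here means a weaker inhibitor, a lower number a stronger inhibitor), compound 1 gives 100000 nM, level with compound 2 `CCC(=O)N1N=C(c2ccccc2)CC1c1ccc(C)cc1`, which gives 100000 nM; no change at the digits printed from compound 1 to compound 2 (within the scatter). Compound 3 `CCC(=O)N1N=C(c2ccc(F)cc2)CC1c1ccc(C)cc1` gives 151 nM, and a 660-fold lower number from compound 2 to compound 3 (2.82 log units; beyond the scatter). Compound 4 `CCC(=O)N1N=C(c2ccc(OC)cc2)CC1c1ccc(Cl)cc1` differs from compound 1 by methoxy in place of hydrogen on an aromatic carbon. For the measured compounds named here, no measured pair shows a methoxy entering at this place; the only step that bears on it is the one from compound 2 to compound 3, where a fluoro entering on the same ring gave a large drop in this assay. That step was measured on a different partner ring and with a different group, so it serves as a rough guide only. He therefore expects a lower number for compound 4, though with wide uncertainty about how far the drop would go: a 20-fold lower number from compound 1 to compound 4 (1.30 log units; beyond the scatter). His estimate for compound 4 in this assay is 5000 nM, in a range from 300 nM to 100000 nM.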

Compound 4, half-maximal inhibitory concentration: 851 nM
Compound 4: the middle estimate sits 5.9-fold (0.77 log units) above what was measured; the measured number falls inside the stated range.
By their numbers in this assay, from the lowest: compound 3; then compound 4; then compounds 1 and 2 (each within the scatter of the next).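

In this assay, methoxy in place of hydrogen on an aromatic carbon, para to a large group, gives a 120-fold lower number from compound 1 to compound 4 (2.07 log units; beyond the scatter), so this place on the ring now has a direct measurement on a chloro partner ring. Together with a 660-fold lower number from compound 2 to compound 3 (2.82 log units; beyond the scatter), it shows that two different groups entering at this place, methoxy and fluoro, each bring a large step on their own partner ring, whereas the change on the partner ring from chloro to methyl, no change at the digits printed from compound 1 to compound 2 (within the scatter), showed no such effect. Nothing at hand explains why the phenyl to 4-methoxyphenyl change has this effect.

The compounds shown leave open whether an amine or a carboxylic acid at this place would also lower the number, and whether a longer chain such as ethoxy would match methoxy. They also leave open how methoxy behaves with the methyl group on the partner ring.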